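Methoxy on Two Cores in a Cytotoxicity Assay

A few compounds are considered here, and "the series" means these few. Any claim that something is new, unique, unknown or untested is made for them only; others in the source may bear on it.

Compound 1 `CC(=O)Nc1ccc(O)c(C(=O)/C=C/c2ccccc2)c1` and compound 2 `COc1ccccc1/C=C/C(=O)c1cc(NC(C)=O)ccc1O` share one core. In an ADME assay on THP-1 cells (Homo sapiens) for cytotoxicity, read by flow cytometry and propidium iodide staining, with a stated time of 72 h (on this read-out lower numbers stand for stronger inhibition and higher numbers for weaker inhibition), compound 1 gives 85500 nM. For compound 2 the result in this assay is a limit of the assay rather than a number, > 125000 nM. The step, an at least 1.4-fold higher number from compound 1 to compound 2 (0.16 log units; that floor lies within the scatter), is set by the methoxy in place of hydrogen on an aromatic carbon and by the limit of > 125000 nM in this assay, at which 1 of the 3 values shown sits.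

Compound 3 `Nc1ccc2oc(-c3ccccc3)c(O)c(=O)c2c1` has a different core, and the difference between the two cores is not broken down here. In this assay compound 3 gives 27000 nM, a lower number than compound 1 shows.

Compound 4 `COc1ccc(-c2oc3ccc(N)cc3c(=O)c2O)cc1` is compound 3 with the same kind of change, methoxy in place of hydrogen on an aromatic carbon. The surroundings are not identical: in compound 2 the methoxy sits ortho to a large group, whereas in compound 4 it sits para to a large group.

The expected step from compound 3 to compound 4 is a 1.4-fold higher number from compound 3 to compound 4 (0.15 log units; within the scatter), a modest rise in the number, resting on the measured step of an at least 1.4-fold higher number from compound 1 to compound 2 (0.16 log units; that floor lies within the scatter), whose floor lies within the scatter. Compound 4 is therefore estimated at 38000 nM in this assay, with a likely range from 18000 nM to 90000 nM.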

Compound 4, half-maximal inhibitory concentration: 29000 nM
Compound 4: the middle estimate sits 1.3-fold (0.12 log units) above what was measured; measured number inside the range.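

On the core of compound 3, methoxy in place of hydrogen on an aromatic carbon, para to a large group, gives a 1.1-fold higher number from compound 3 to compound 4 (0.03 log units; within the scatter) in this assay, so on this core the change has no effect that can be told apart from the usual variation between repeat measurements. These compounds do not show whether the change has the same size on both cores, only that nothing here establishes a difference: the same change on two cores in this assay, an at least 1.4-fold higher number (0.16 log units; that floor lies within the scatter) from compound 1 to compound 2 and a 1.1-fold higher number (0.03 log units; within the scatter) from compound 3 to compound 4; the limit leaves it open whether they differ The result for compound 2 is a limit of the assay and not a number, so the step on the first core has a floor but no known size, and it gives no firm figure to carry over to the other core: the limit of > 125000 nM in this assay, at which 1 of the 4 values shown sits.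

Each core is represented by a single pair, hydrogen against methoxy, and the methoxy sits in different surroundings in the two pairs, so a pair with the methoxy in matching surroundings on both cores would be needed for a cleaner comparison. From the compounds shown here alone, how a different group, such as a hydroxyl, an ethoxy or a fluorine, would read in this assay on either core also remains open.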